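Ester to Methylamide: What to Expect for Compound 4

The source may report more compounds than this note shows. Statements on the series, on what has been measured and on what is new or still open speak of the compounds shown alone.

Of the compounds shown here, three have so far been measured in an assay on isolated protein for inhibition of Gonadotropin-releasing hormone receptor (Homo sapiens); on this read-out higher numbers stand for weaker inhibition and lower numbers for stronger inhibition. Compound 1 `COc1ccc(C#N)cc1CSc1nc2cc(NC(=O)C3CC3)ccc2n1C(C)C` gives 570 nM in this assay, compound 2 `COc1ccc([N+](=O)[O-])cc1CSc1nc2cc(NC(=O)C(C)(C)C)ccc2n1C(C)C` gives 180 nM, and compound 3 `CCCn1c(SCc2cc([N+](=O)[O-])ccc2OC)nc2cc(NC(=O)NC(C)(C)C)cc(C(=O)OC)c21` gives 37 nM. Compound 3 thus shows the lowest number of the three: compound 2 comes nearest, its number sitting beyond the scatter above that of compound 3, and compound 1 stands furthest away, again beyond the scatter. On these numbers compound 3 is the strongest inhibitor of the set.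

Compound 4 `CCCn1c(SCc2cc([N+](=O)[O-])ccc2OC)nc2cc(NC(=O)NC(C)(C)C)cc(C(=O)NC)c21` has not yet been measured. It differs from compound 3 in a single place: methylamino in place of methoxy on a carbonyl carbon. Within the data shown here, no pair of measured compounds differs in just this way, so there is no measured step to lean on, and the expectation rests on compound 3 alone, with its value of 37 nM. With nothing in the data pointing either way, the step from compound 3 to compound 4 is expected to be small, a 1.1-fold higher number from compound 3 to compound 4 (0.03 log units; within the scatter), possibly none beyond the scatter in either direction. Compound 4 is therefore estimated to give about 40 nM, within a range from 12 nM to 130 nM, in this assay.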

Compound 4, half-maximal inhibitory concentration: 41 nM
For compound 4 the middle estimate is 1.0-fold (0.01 log units) below the measured one; low and high end bracket the measured number.
By their numbers in this assay, from the lowest: compounds 3 and 4 (each within the scatter of the next); then compound 2; then compound 1.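

Among these compounds, this is the first comparison in the set that differs in one place only, and in this assay methylamino in place of methoxy on a carbonyl carbon gives a 1.1-fold higher number from compound 3 to compound 4 (0.04 log units; within the scatter). The two groups differ in their counts, with methylamino carrying a hydrogen-bond donor and methoxy a hydrogen-bond acceptor, yet the read-out does not tell compound 3 and compound 4 apart, so at this position the methylcarbamoyl and methoxycarbonyl groups cannot be distinguished on this measure. No measured information is at hand to explain this result.

The compounds shown leave open how a carboxylic acid, a dimethylamino group or a longer chain such as ethylamino on this carbonyl carbon would read in this assay. Among the compounds shown here, they also leave open whether this step would hold with the propyl chain or the tert-butyl urea replaced, as only a single pair of compounds carries this change.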